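The source may hold more compounds than are shown below. What is called first, only, known or untested is meant among the compounds shown, and "the series" means these compounds.

Measured in a functional assay on HepG2 cells (Homo sapiens) for cytotoxicity; a higher number here means a weaker inhibitor, a lower number a stronger inhibitor:
- compound 1 `O=S(=O)(N/C(=N\O)Nc1ccc(Cl)cc1)c1ccccc1`: 54 ug/mL
- compound 2 `Cc1c(S(=O)(=O)N/C(=N\O)Nc2ccc(Cl)cc2)sc2ccc(Cl)cc12`: 140 ug/mL
- compound 3 `O=[N+]([O-])c1ccc(Oc2c(Cl)cc(S(=O)(=O)N/C(=N\O)Nc3ccc(Cl)cc3)cc2Cl)c(Cl)c1`: 49 ug/mL

Compound 1, at 54 ug/mL, is level within the scatter with compound 3, while compound 2 reads higher at 140 ug/mL. Compound 4 `CCCCOc1ccc(S(=O)(=O)N/C(=N\O)Nc2ccc(Cl)cc2)cc1` has butoxy in place of hydrogen on an aromatic carbon, para to a large group (butoxy in place of hydrogen on an aromatic carbon). Among the compounds with values here, no measured pair differs in one place, so nothing measured sizes this change. With much added to the core of compound 1, compound 3 still gives 49 ug/mL, which suggests a modest effect. The expected step is a 1.1-fold higher number from compound 1 to compound 4 (0.05 log units; within the scatter), a slightly higher number but none beyond the scatter. For compound 4 the estimated value is 60 ug/mL, with an expected range from 25 ug/mL to 140 ug/mL.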

Compound 4, half-maximal inhibitory concentration: 63 ug/mL
Beside the measured number, compound 4's estimate is 1.1-fold (0.02 log units) below it; low and high end bracket the measured number.
By their numbers in this assay, from the lowest: compounds 3, 1 and 4 (each within the scatter of the next); then compound 2.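

In this assay, within the data shown here, butoxy in place of hydrogen on an aromatic carbon, para to a large group, gives a 1.2-fold higher number from compound 1 to compound 4 (0.07 log units; within the scatter), the first change in one place that can be sized here. Among these compounds, at this position, then, a chain of this size leaves the number level with that of compound 1, which the earlier compounds could only suggest. Nothing available accounts for this result. From the compounds shown here alone, whether methoxy, a longer chain, an amine or a carboxylic acid at this position would also stay level remains open.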